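A few compounds are considered here, and "the series" means these few. Any claim that something is new, unique, unknown or untested is made for them only; others in the source may bear on it.

Working notes on the series. Compound 1 `CCCCN(CC)c1cc(C)nc2c1NC(=O)CN2c1ccc(C)cc1Cl` is recorded in an assay on HEK-293T cells for displacement of a labelled ligand from corticotropin-releasing factor receptor 2 (Homo sapiens), read by scintillation counting, with a stated time of 2 h, tested at 1 uM (a higher number here means more inhibition at the concentration tested (going by the name of the read-out), a lower number less inhibition), as "not determined" (no result reported). Compound 2 `CCCCN(CC)c1cc(C)nc2c1NC(=O)CN2c1ccc(C(C)(C)C)cc1Br` gives -3.8% in this assay, the only number shown for the series, so compound 2 stands alone with no measured neighbour for comparison. Compound 3 `CCCCN(CC)c1cc(C)nc2c1NC(=O)CN2c1ccc(Br)cc1Br` is the next entry, differing from compound 2 by bromo in place of tert-butyl on an aromatic carbon. Nothing measured tells how such a change moves the read-out here. For compound 3 the expected step is a number 5.8 percentage points higher from compound 2 to compound 3 (within the scatter), which is none beyond the scatter. Compound 3 is estimated at 2% in this assay, within -15% to 25%.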

Compound 3, a percentage reported as inhibition, at one concentration (the size of the read-out at that concentration, not a potency): 9.4%
Estimate against measurement, compound 3: 7.4 percentage points below, and the stated range covers the measured number.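

Bromo in place of tert-butyl on this aromatic carbon, meta to a bromo group, gives a number 13.2 percentage points higher from compound 2 to compound 3 (beyond the scatter) in this assay. For the compounds shown here, this is the first sign that the read-out responds to the group at this position, though the step is modest. Nothing available bears on the origin of this step. Still open, on these data alone, is how an amine or a carboxylic acid on this carbon would move the read-out. Also open, as far as these compounds go, is whether a longer chain in place of the butyl group would change it.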